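From 4-(dimethylamino)phenyl to 3-nitrophenyl at an assay limit

The source may report more compounds than this note shows. Statements on the series, on what has been measured and on what is new or still open speak of the compounds shown alone.

In a functional assay on UACC-62 cells (Homo sapiens) for cytotoxicity, read by sulforhodamine B assay (a higher number here means a weaker inhibitor of growth, a lower number a stronger inhibitor of growth), compound 3 `CC1=CC[C@@H]([C@@](C)(O)CCCC(C)(C)NC(=S)N/N=C\c2ccc(N(C)C)cc2)CC1` gives only a limit, > 100000 nM, and no exact number. Compound 1 `CC1=CC[C@@H]([C@@](C)(O)CCCC(C)(C)NC(=S)N/N=C\c2ccccc2)CC1` gives 43800 nM, and compound 2 `COc1ccc(/C=N\NC(=S)NC(C)(C)CCC[C@](C)(O)[C@@H]2CC=C(C)CC2)cc1` gives 22100 nM. Between these two the change is a 2.0-fold lower number from compound 1 to compound 2 (0.30 log units; within the scatter). Compound 4 `CC1=CC[C@@H]([C@@](C)(O)CCCC(C)(C)NC(=S)N/N=C\c2cccc([N+](=O)[O-])c2)CC1` differs from compound 3 as follows: 3-nitrophenyl in place of 4-(dimethylamino)phenyl on a carbon with a double bond to nitrogen. In short, 3-nitrophenyl stands in place of 4-(dimethylamino)phenyl. Two measured steps introduce the dimethylamino group: an at least 2.2-fold higher number from compound 1 to compound 3 (0.35 log units; beyond the scatter), and an at least 4.5-fold higher number from compound 2 to compound 3 (0.65 log units; beyond the scatter). Going by the values given here, compound 4 lacks that group, so compound 1 at 43800 nM and compound 2 at 22100 nM are the closest guides, although no nitro compound has been measured yet. A lower number is therefore expected, as an at least 2.8-fold lower number from compound 3 to compound 4 (0.45 log units; beyond the scatter). For compound 4 the estimated value is 35000 nM, with an expected range of 12000 nM to 100000 nM.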

Compound 4, concentration for total growth inhibition: 24700 nM
Beside the measured number, compound 4's estimate is 1.4-fold (0.15 log units) above it; measured number inside the range.
By their numbers in this assay, from the lowest: compounds 2, 4 and 1 (each within the scatter of the next). At a limit, above all of these: compound 3.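

In this assay, 3-nitrophenyl in place of 4-(dimethylamino)phenyl gives an at least 4.0-fold lower number from compound 3 to compound 4 (0.60 log units; beyond the scatter). Going by these compounds alone, that step starts from a limit and not from an exact number: the limit of > 100000 nM in this assay, at which 1 of the 4 values shown sits. The new nitro group also stays within the scatter of the earlier compounds, with a 1.8-fold lower number from compound 1 to compound 4 (0.25 log units; within the scatter) and a 1.1-fold higher number from compound 2 to compound 4 (0.05 log units; within the scatter), so among the four compounds only the one carrying 4-(dimethylamino)phenyl stands apart.

Going by these compounds, whether a primary amine or a carboxylic acid on this aromatic ring would group with compound 3 stays open. Also open, on these data alone, is whether any group there could bring the number clearly below those of compound 1, compound 2 and compound 4.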